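A few compounds are considered here, and "the series" means these few. Any claim that something is new, unique, unknown or untested is made for them only; others in the source may bear on it.

Measured compounds:
- compound 1, `COc1ccc(-c2nc(SCC(=O)c3sc(-c4ccccc4)nc3C)nc(N)c2C#N)cc1`, 17.2%
- compound 2, `COc1ccc(-c2nc(C)c(C(=O)CSc3nc(-c4ccc(Cl)cc4)c(C#N)c(=O)[nH]3)s2)cc1`, 2.85%
- compound 3, `Cc1nc(-c2ccccc2)sc1C(=O)CSc1nc(N)c(C#N)c(-c2ccccc2)n1`, 6.48%

In a functional assay on U-87MG ATCC cells for antiproliferative activity against U-87 MG (Homo sapiens), read by MTT assay, with a stated time of 48 h, tested at 100 uM (on this read-out lower numbers stand for a stronger effect and higher numbers for a weaker effect at the one concentration tested), compound 1 gives 17.2%, the highest of the three numbers, so the weakest effect of the set. Going by the values given here, compound 3 stands nearest to it, and the only step between compounds that differ in one place, a number 10.7 percentage points lower from compound 1 to compound 3 (beyond the scatter), is a modest one, beyond the scatter. Among the compounds with values here, compound 2 carries a different core and its value, 2.85%, is simply the lowest of the three, with no single-point step connecting it to compound 1.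

Compound 4, `COc1ccc(-c2nc(C)c(C(=O)CSc3nc(N)c(C#N)c(-c4ccc(OC)cc4)n3)s2)cc1`, differs from compound 1 by methoxy in place of hydrogen on an aromatic carbon. Within the data shown here, the only step that bears on this, from compound 1 to compound 3, removed a methoxy from a different aromatic ring and lowered the number; the new methoxy enters on the ring attached to the core of compound 1, where no step is known. The bearing is therefore indirect. A small rise is expected, a number 3.8 percentage points higher from compound 1 to compound 4 (within the scatter), but it may well fall within the scatter. Compound 4 is expected to give about 21% in this assay, with a range from 8% to 38%.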

Compound 4, a percentage reported as activity, at one concentration (the size of the read-out at that concentration, not a potency): 0.26%
Compound 4: the middle estimate sits 20.7 percentage points above what was measured; measured number below the stated range.
By their numbers in this assay, from the lowest: compounds 4, 2 and 3 (each within the scatter of the next); then compound 1.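

Going by these compounds alone, putting methoxy in place of hydrogen on this phenyl group, on an aromatic carbon para to a large group, gives a step beyond the scatter in this assay: a number 16.9 percentage points lower from compound 1 to compound 4 (beyond the scatter) is the first sign that this position responds to a substitution at all. Taking methoxy off the other aromatic ring points the same way, as a number 10.7 percentage points lower from compound 1 to compound 3 (beyond the scatter) shows, so among these compounds compound 1 stands above both of its neighbours, and adding a methoxy on one ring and removing one from the other each go with a lower number, which means that no simple rule of more or less methoxy covers the two rings. Nothing at hand gives a measured property that would account for this step.

From the compounds shown here alone, only hydrogen and methoxy are seen at this position, so it remains open whether a hydroxy group, a chlorine atom, an amine or a longer ethoxy chain in the same place would give a similar number. With a reading at a single concentration, the compounds shown also leave open how far the step from phenyl to 4-methoxyphenyl would carry over into potency.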